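Trimming a Ring Substituent on a Receptor Ligand

The compounds below may be only part of what the source reports. "The series", "measured", "known", "first", "only" and "open" are said of these compounds alone.

Compound 1 `Cc1nc(N2CCN(C3CCCC3)CC2)nc2ccc(NC(=O)COc3ccc(Cl)cc3)cc12` carries a cyclopentyl group on the amine nitrogen of its six-membered ring. In an assay on CHO-K1 cells for displacement of a labelled ligand from melanin-concentrating hormone receptor 1 (Homo sapiens), with a stated time of 2 h (on this read-out higher numbers stand for weaker inhibition and lower numbers for stronger inhibition), compound 1 gives 96 nM, the highest number of the three measured compounds. Compound 2 `Cc1nc(N2CCC(NC(=O)C(C)C)CC2)nc2ccc(NC(=O)COc3ccc(Cl)cc3)cc12` gives 15 nM in this assay, and compound 3 `Cc1nc(N2CCC(C(=O)NC(C)C)CC2)nc2ccc(NC(=O)COc3ccc(Cl)cc3)cc12` gives 15 nM. Within the data shown here, compound 2 and compound 3 share a different saturated ring from compound 1, and the only single-point step among the measured compounds, no change at the digits printed from compound 2 to compound 3 (within the scatter), concerns a group on that ring rather than the ring nitrogen altered here.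

Compound 4 `Cc1nc(N2CCN(C)CC2)nc2ccc(NC(=O)COc3ccc(Cl)cc3)cc12` differs from compound 1 by methyl in place of cyclopentyl on an amine nitrogen in a ring. Among the measured compounds shown here, no measured pair makes this change or any change at this nitrogen, so the data give no direct guide to its size or direction; the gap between compound 1 and the other two cannot be assigned to this position either.

Compound 4 is therefore expected, with wide uncertainty, to give about 250 nM in this assay, somewhere between 60 nM and 1000 nM. The step of a 2.6-fold higher number from compound 1 to compound 4 (0.42 log units; beyond the scatter) is expected to be a modest move toward weaker inhibition, possibly within the scatter.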

Compound 4, half-maximal inhibitory concentration: 220 nM
Estimate against measurement, compound 4: 1.1-fold (0.06 log units) above, within the range that was stated.
By their numbers in this assay, from the lowest: compounds 2 and 3 (each within the scatter of the next); then compound 1; then compound 4.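

Among these compounds, this is the first measured change at the amine nitrogen of the six-membered ring: in this assay, methyl in place of cyclopentyl gives a 2.3-fold higher number from compound 1 to compound 4 (0.36 log units; beyond the scatter) as a modest step toward weaker inhibition, so the group on this nitrogen does affect the read-out. Binding is still measurable with only a single carbon there, as compound 4 gives 220 nM in the same assay, so the five-membered carbon ring is not essential for displacing the labelled ligand. By the printed counts, neither group has hydrogen-bond donors or acceptors or a net charge, and nothing measured here explains the difference.

As far as these compounds go, whether ethyl, isopropyl or cyclohexyl on this nitrogen would continue the same order remains open. So does the effect of an amide-bearing chain at this position.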